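Swapping 4-methylpiperazin-1-yl on a Chain at the Limit

A few compounds are considered here, and "the series" means these few. Any claim that something is new, unique, unknown or untested is made for them only; others in the source may bear on it.

Compound 1 `Cn1c(N)c(-c2nc3ccccc3[nH]2)c2nc(C#N)c(C#N)nc21` gives > 50000 nM in a functional assay on Raji cells (Homo sapiens) for antiproliferative activity, read by MTT assay, with a stated time of 48 h (a higher number here means a weaker inhibitor, a lower number a stronger inhibitor), which is a limit and not a number. Compound 2 `CN1CCN(CCn2c(N)c(-c3nc4ccccc4[nH]3)c3nc(C#N)c(C#N)nc32)CC1` also reaches only a limit, > 50000 nM. Compound 3 `N#Cc1nc2c(-c3nc4ccccc4[nH]3)c(N)n(CCCO)c2nc1C#N` likewise gives a limit, > 50000 nM. Among the compounds with values here, compound 2 therefore has no exact potency, and the whole series so far reads (the limit of > 50000 nM in this assay, at which 3 of the 3 values shown sit).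

Compound 4 `N#Cc1nc2c(-c3nc4ccccc4[nH]3)c(N)n(CCCN3CCCCC3)c2nc1C#N` differs from compound 2 in one place: (piperidin-1-yl)methyl in place of 4-methylpiperazin-1-yl on a saturated chain carbon, two bonds along the chain from an aromatic nitrogen. Put simply, (piperidin-1-yl)methyl stands in place of 4-methylpiperazin-1-yl on a saturated chain carbon, two bonds along the chain from an aromatic nitrogen.

Within the data shown here, three measured steps bear on this change: a step that the two limits leave unreadable from compound 1 to compound 2, a step that the two limits leave unreadable from compound 1 to compound 3 and a step that the two limits leave unreadable from compound 2 to compound 3. The last changes the same place on the chain, yet none of them gives a size to carry over. No shift beyond the scatter, in either direction, is therefore expected in this assay, and the estimated step is a number no higher from compound 2 to compound 4 (the limit leaves the size open). A limit is again the likeliest result. If a number does appear, compound 4 is expected at 50000 nM, within an estimated range of 12000 nM to 100000 nM.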

Compound 4, half-maximal inhibitory concentration: 3380 nM
Compound 4: middle estimate off by 15-fold (1.17 log units), on the high side; measured number outside the range, below it.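

Within the data shown here, compound 4 is the first to give a number instead of a limit in this assay: the limit of > 50000 nM in this assay, at which 3 of the 4 values shown sit. Going from 2-(4-methylpiperazin-1-yl)ethyl to 3-(piperidin-1-yl)propyl gives an at least 14-fold lower number from compound 2 to compound 4 (1.17 log units; beyond the scatter), so activity at this position responds to what stands on the chain, which the earlier compounds could not show. Piperidin-1-yl in place of hydroxy gives an at least 14-fold lower number from compound 3 to compound 4 (1.17 log units; beyond the scatter), and 2-(piperidin-1-yl)ethyl in place of hydrogen gives an at least 14-fold lower number from compound 1 to compound 4 (1.17 log units; beyond the scatter).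

The steps among compound 1, compound 2 and compound 3 cannot be read, and the step to compound 4 from compound 2 changes both the ring and the chain length. A 3-(4-methylpiperazin-1-yl)propyl or a 2-(piperidin-1-yl)ethyl group on the same core would separate those two changes.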